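The source may report more compounds than this note shows. Statements on the series, on what has been measured and on what is new or still open speak of the compounds shown alone.

Compound 3 `O=C(/C=C/c1cccnc1)NCCCCCCc1cccc(S(=O)(=O)Nc2ccccc2)c1` shows the lowest number among the three measured compounds in an assay on isolated protein for inhibition of Nicotinamide phosphoribosyltransferase (Homo sapiens), read by WST assay, with stated times of 60 min, 5 min and 30 min, in the presence of a further agent that is not named here (on this read-out lower numbers stand for stronger inhibition and higher numbers for weaker inhibition), giving 10.5 nM. Compound 1 `O=C(/C=C/c1cccnc1)NCCCCc1ccc(S(=O)(=O)Nc2ccccc2)cc1` gives 17.8 nM in this assay, a result that sits within the usual scatter of compound 3, so the two cannot be told apart on these numbers. Compound 2 `O=C(/C=C/c1cccnc1)NCCCc1ccc(S(=O)(=O)Nc2ccccc2)cc1`, by contrast, gives 5920 nM in this assay, a number far weaker than that of compound 3 and well beyond the scatter.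

Compound 4 `O=C(/C=C/c1cccnc1)NCCCCCCc1cccc(S(=O)(=O)Nc2ccc(Cl)cc2)c1` keeps the whole of compound 3 apart from one change: chloro in place of hydrogen on an aromatic carbon. Among the measured compounds shown here, no measured pair among the three compounds differs only in a substituent on the anilino ring, so there is no step of this kind to lean on. The measured compounds differ in the chain and in the attachment to the sulfonamide-bearing ring, not in the phenylsulfamoyl part, and so they say nothing direct about a chloro at this place.

On that basis a step no larger than the scatter is expected for a 1.1-fold lower number from compound 3 to compound 4 (0.02 log units; within the scatter), in no firm direction. Compound 4 is estimated to give 10 nM in this assay, with a range from 3 nM to 35 nM.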

Compound 4, half-maximal inhibitory concentration: 10.8 nM
Compound 4: middle estimate off by 1.1-fold (0.03 log units), on the low side; the measured number falls inside the stated range.
By their numbers in this assay, from the lowest: compounds 3, 4 and 1 (each within the scatter of the next); then compound 2.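

In this assay, chloro in place of hydrogen on an aromatic carbon of the anilino ring, para to a large group, gives a 1.0-fold higher number from compound 3 to compound 4 (0.01 log units; within the scatter) and so leaves compound 3 and compound 4 indistinguishable on these numbers. Among the compounds shown here, this is the first look at the phenylsulfamoyl part, since the earlier compounds differ in the chain and in the attachment to the sulfonamide-bearing ring, and it shows that this place takes one added chlorine atom with no step beyond the scatter, at least alongside the chain and attachment of compound 3. Nothing measured here bears on why the two compounds agree.

The compounds shown leave open whether a fluoro, a methoxy, a trifluoromethyl, an amine or a carboxylic acid at this same place would also stay within the scatter of compound 3, and whether a larger group such as a second phenyl ring would do so. They also leave open whether chloro elsewhere on the anilino ring, or chloro at this place on the shorter chain of compound 1, would give a similar result.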